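The source may hold more compounds than are shown below. What is called first, only, known or untested is meant among the compounds shown, and "the series" means these compounds.

Compound 1 `O=C(NCCCCCCNc1ncnc2c1ncn2[C@@H]1O[C@H](CO)[C@@H](O)[C@H]1O)C1=CC2C=CC1CC2` and compound 2 `O=C(NCCCCCCCCCCNc1ncnc2c1ncn2[C@@H]1O[C@H](CO)[C@@H](O)[C@H]1O)C1=CC2C=CC1CC2` share a core and differ in the length of the chain that carries the amide. In an assay on Flp-In-CHO cells for agonist activity at adenosine receptor A1 (Homo sapiens), read by ERK phosphorylation, with a stated time of 5 min (a lower number here means that less compound is needed, a higher number that more compound is needed for the effect), compound 1 gives 15.9 nM, and compound 2 gives 25.1 nM, which is the highest of the two numbers; the two values lie within the scatter of each other, so no order between them is claimed. Compound 3 `OC[C@H]1O[C@@H](n2cnc3c(NCCCCCCCCCCN=C=S)ncnc32)[C@H](O)[C@@H]1O` keeps the longer chain of compound 2 but carries a different end group: a group of 3 heavy atoms (1 carbon, 1 nitrogen, 1 sulfur; no ring) in place of a group of 11 heavy atoms (9 carbon, 1 nitrogen, 1 oxygen; 2 six-membered non-aromatic rings of carbon only), on a saturated chain carbon, ten or more bonds along the chain from a nitrogen on an aromatic ring. For the measured compounds named here, no measured pair shows the effect of such a change, so no step beyond the scatter is assumed in either direction. Compound 3 is expected to give 30 nM in this assay, with a range from 8 nM to 120 nM, which would mean a step of a 1.2-fold higher number from compound 2 to compound 3 (0.08 log units; within the scatter).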

Compound 3, half-maximal effective concentration: 79.4 nM
For compound 3 the middle estimate is 2.6-fold (0.42 log units) below the measured one, within the range that was stated.
By their numbers in this assay, from the lowest: compounds 1 and 2 (each within the scatter of the next); then compound 3.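

In this assay, the group of 3 heavy atoms in place of the group of 11 heavy atoms gives a step beyond the scatter (a 3.2-fold higher number from compound 2 to compound 3 (0.50 log units; beyond the scatter)), so the end of the chain responds to a change of group, which compounds 1 and 2, differing only in chain length, could not show. The step measured against the shorter chain is also beyond the scatter (a 5.0-fold higher number from compound 1 to compound 3 (0.70 log units; beyond the scatter)). The data offer no explanation for these steps.

On these data alone, whether an amine or a carboxylic acid at this place would give a number closer to that of compound 2 remains open. So does the effect of the group of 3 heavy atoms on the shorter chain of compound 1.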